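A few compounds are considered here, and "the series" means these few. Any claim that something is new, unique, unknown or untested is made for them only; others in the source may bear on it.

In a functional assay on A549 cells (Homo sapiens) for antiproliferative activity, read by MTT assay (a lower number here means a stronger inhibitor, a higher number a weaker inhibitor), compound 1 `Cc1nn2c(-c3nc4cc(Cl)ccc4[nH]3)c(-c3ccccc3)nc2s1` gives 16900 nM and compound 2 `Cc1nn2c(-c3nc4cc(Cl)c(F)cc4[nH]3)c(-c3ccccc3)nc2s1` gives 16400 nM, so these two share the high end of the measured values. Compound 3 `Cc1ccc(-c2nc3sc(C)nn3c2-c2nc3cc(Cl)ccc3[nH]2)cc1` gives 4400 nM. Compound 4 `Cc1nn2c(-c3nc4cc(O)ccc4[nH]3)c(-c3ccccc3)nc2s1` is the next to consider, and its difference from compound 1 is hydroxy in place of chloro on an aromatic carbon. Two measured steps offer some guidance: a 1.0-fold lower number from compound 1 to compound 2 (0.01 log units; within the scatter) and a 3.8-fold lower number from compound 1 to compound 3 (0.58 log units; beyond the scatter). Neither swaps chloro for hydroxy, so neither measures this change directly, and the data give no basis for choosing a direction. The expected outcome is a 1.1-fold lower number from compound 1 to compound 4 (0.05 log units; within the scatter), which means no step beyond the scatter. Compound 4 is estimated at 15000 nM, within an expected range of 6000 nM to 40000 nM.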

Compound 4, half-maximal inhibitory concentration: 19400 nM
Estimate against measurement, compound 4: 1.3-fold (0.11 log units) below; the measured number falls inside the stated range.
By their numbers in this assay, from the lowest: compound 3; then compounds 2, 1 and 4 (each within the scatter of the next).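

In this assay the swap of chloro for hydroxy on this aromatic carbon gives a 1.1-fold higher number from compound 1 to compound 4 (0.06 log units; within the scatter) and so makes no real difference. Going by these compounds alone, the earlier compounds left the chloro in place, so this is the first sign that the position can take a group with a hydrogen-bond donor and acceptor without a change beyond the scatter. No measurement here explains this result. From the compounds shown here alone, whether an amine or a carboxylic acid on this carbon would also leave the number unchanged remains open.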